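Replacing chloro with methylamino on a weakly active core

The source may report more compounds than this note shows. Statements on the series, on what has been measured and on what is new or still open speak of the compounds shown alone.

Compound 1 `OC[C@@H](O)[C@H]1O[C@@H](n2cnc3c(Cl)ncnc32)[C@H](O)[C@@H]1O`: > 100000 nM
Compound 2 `OC[C@@H](O)[C@H]1O[C@@H](n2cnc3c(Cl)nc(Cl)nc32)[C@H](O)[C@@H]1O`: 47100 nM
Compound 3 `Nc1nc(Cl)nc2c1ncn2[C@@H]1O[C@H]([C@H](O)CO)[C@@H](O)[C@H]1O`: > 100000 nM

In a functional assay on HeLa cells (Homo sapiens), read by colorimetric assay, with a stated time of 48 h (a higher number here means a weaker inhibitor, a lower number a stronger inhibitor), compound 1 gives > 100000 nM, which is a limit and not a number. Compound 1 therefore stands at the limit of > 100000 nM in this assay, at which 2 of the 3 values shown sit. Compound 3 gives > 100000 nM, also a limit. Unmeasured compound 4 `CNc1ncnc2c1ncn2[C@@H]1O[C@H]([C@H](O)CO)[C@@H](O)[C@H]1O` carries methylamino in place of chloro on an aromatic carbon.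

The closest measured change, amino in place of chloro on an aromatic carbon, gave an at least 2.1-fold higher number from compound 2 to compound 3 (0.32 log units; beyond the scatter). The other step, chloro in place of hydrogen on an aromatic carbon, gave an at least 2.1-fold lower number from compound 1 to compound 2 (0.32 log units; beyond the scatter). Neither step points to a gain, so the expected outcome in this assay is a number no higher from compound 1 to compound 4 (the limit leaves the size open). Compound 4 is estimated at 100000 nM, with an expected range of 40000 nM to 250000 nM.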

Compound 4, half-maximal inhibitory concentration: > 100000 nM
Compound 4: only a limit was reported (the forecaster's own chance of this, stated with the estimate: 80%); the middle value sits exactly at the limit.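

Within the data shown here, compound 1 and compound 4 both stop at a limit in this assay, so no step between them can be read: the limit of > 100000 nM in this assay, at which 3 of the 4 values shown sit. From the compounds shown here alone, whether methylamino in place of chloro changes the number at all stays open.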